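Compound 2 to compound 3: a cyclopropyl swap

The compounds below may be only part of what the source reports. "The series", "measured", "known", "first", "only" and "open" are said of these compounds alone.

In an in vitro ADME assay on microsomes (Rattus norvegicus) for metabolic stability (a lower number here means that the compound disappears faster, a higher number that the compound lasts longer), compound 1 (`CCc1nc(-c2ccc(Cl)cc2Cl)c(CC)nc1NC(C1CC1)C1CC1`) gives 0.0417 h as its half-life. Compound 2 (`CCCN(CCN(C)C)c1nc(CC)c(-c2ccc(Cl)cc2Cl)nc1CC`) gives < 0.0167 h as its half-life, and that is a limit of the assay, not a number. It therefore stands at the limit of < 0.0167 h in this assay, at which 1 of the 2 values shown sits, and has no exact place on the scale.

Compound 3 (`CCCN(CC1CC1)c1nc(CC)c(-c2ccc(Cl)cc2Cl)nc1CC`) carries cyclopropyl in place of (dimethylamino)methyl on a saturated chain carbon bound to a nitrogen on an aromatic ring. Going by the values given here, the one measured step that bears on this, with (2-(dimethylamino)ethyl)(propyl)amino in place of (dicyclopropylmethyl)amino, is an at least 2.4-fold lower number from compound 1 to compound 2 (0.39 log units; beyond the scatter) and lies beyond the scatter. Compound 3 carries cyclopropyl as compound 1 does, so a part of an at least 2.4-fold lower number from compound 1 to compound 2 (0.39 log units; beyond the scatter) may be regained, and a small rise is expected in this assay for compound 3. The expected change is an at least 1.4-fold higher number from compound 2 to compound 3 (0.17 log units; that floor lies within the scatter) on this estimate. Compound 3 is estimated at 0.025 h as its half-life, with an expected range from 0.014 h to 0.05 h for repeat measurements.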

Compound 3, half-life: 0.07 h
Compound 3: the middle estimate sits 2.8-fold (0.45 log units) below what was measured, and the stated range ends below it.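

In this assay, cyclopropyl in place of (dimethylamino)methyl on a saturated chain carbon bound to a nitrogen on an aromatic ring gives an at least 4.1-fold higher number from compound 2 to compound 3 (0.62 log units; beyond the scatter), so this position clearly responds to the change. Compound 2 stands at a limit of the assay, not a number, so the size of that step is only a floor: the limit of < 0.0167 h in this assay, at which 1 of the 3 values shown sits. (Cyclopropylmethyl)(propyl)amino in place of (dicyclopropylmethyl)amino gives a 1.7-fold higher number from compound 1 to compound 3 (0.22 log units; within the scatter), so a single cyclopropyl in the side chain keeps the half-life level with that of the group carrying two.

The compounds shown leave open whether the cyclopropyl ring itself counts, or only the departure of the dimethylamino group; an isobutyl chain would separate the two. As far as these compounds go, it is also open whether a different amine at the chain end, such as a morpholine, would behave like dimethylamino.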